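A few compounds are considered here, and "the series" means these few. Any claim that something is new, unique, unknown or untested is made for them only; others in the source may bear on it.

Compound 1 `O=C(NC(c1ccc2ccccc2c1)C1CCNCC1)c1ccc2cnccc2c1`: 400 nM
Compound 2 `N#Cc1cc(C(NC(=O)c2ccc3cnccc3c2)C2CCNCC2)ccc1Cl`: 80 nM
Compound 3 `O=C(NC(c1ccc(Cl)cc1)C1CCNCC1)c1ccc2cnccc2c1`: 190 nM

In an assay on isolated protein for inhibition of RAC-alpha serine/threonine-protein kinase (Homo sapiens) (on this read-out higher numbers stand for weaker inhibition and lower numbers for stronger inhibition), compound 3 holds the middle of the three numbers: the step of a 2.1-fold lower number from compound 1 to compound 3 (0.32 log units; beyond the scatter) is modest, and the step of a 2.4-fold higher number from compound 2 to compound 3 (0.38 log units; beyond the scatter) is modest as well. Compound 4 `O=C(NC(c1cnc(Cl)c(Cl)c1)C1CCNCC1)c1ccc2cnccc2c1` differs from compound 3 by 5,6-dichloropyridin-3-yl in place of 4-chlorophenyl on a saturated chain carbon bound to an amide-type nitrogen and a saturated ring carbon. Among the compounds with values here, no measured step makes exactly this change. The nearest comparisons are the modest step of a 2.4-fold higher number from compound 2 to compound 3 (0.38 log units; beyond the scatter), where a second group on the same ring goes with a lower number, and the modest step of a 2.1-fold lower number from compound 1 to compound 3 (0.32 log units; beyond the scatter), where the ring at this place was exchanged. A modest step in the same direction is therefore expected, so compound 4 is estimated at 140 nM, within 60 nM to 350 nM, which means an expected step of a 1.4-fold lower number from compound 3 to compound 4 (0.13 log units; within the scatter).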

Compound 4, half-maximal inhibitory concentration: 140 nM
Beside the measured number, compound 4's estimate shows no gap at the digits printed; the measured number falls inside the stated range.
By their numbers in this assay, from the lowest: compounds 2, 4 and 3 (each within the scatter of the next, the first and the last beyond it); then compound 1.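

At this place on the saturated chain carbon, the aromatic ring can hold a ring nitrogen and a second chlorine together and stay level with the earlier chlorinated phenyl compounds in this assay: a 1.4-fold lower number from compound 3 to compound 4 (0.13 log units; within the scatter) and a 1.8-fold higher number from compound 2 to compound 4 (0.24 log units; within the scatter) both lie within the scatter. Set against naphthalen-2-yl, the step of a 2.9-fold lower number from compound 1 to compound 4 (0.46 log units; beyond the scatter) stands clear of it. Nothing measured here explains these numbers.

As far as these compounds go, the ring nitrogen and the second chlorine enter together, and their separate shares stay open. Also open, from the compounds shown here alone, is how a ring carrying an amine or a carboxylic acid would read at this place.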